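Nitro for methoxy on the pendant phenyl ring

This account rests on a few compounds, and the source may have more. Where it says the series, first, only, none or still open, it means among the compounds named here.

Measured in a functional assay on Bel-7402 cells (Homo sapiens) for cytotoxicity, read by MTT assay, with a stated time of 48 h; a higher number here means a weaker inhibitor, a lower number a stronger inhibitor:
compound 1 `COc1cc(-n2c(-c3ccc([N+](=O)[O-])cc3)cn(C(C)=O)c2=O)cc(OC)c1OC` gives > 50000 nM, a limit of the assay.
compound 2 `COc1ccc(-c2cn(C(C)=O)c(=O)n2-c2cc(OC)c(OC)c(OC)c2)cc1` gives 9500 nM.
compound 3 `COc1ccc(-c2cn(C(C)=O)c(=O)n2-c2cc(OC)c(OC)c(OC)c2)cc1OC` gives > 50000 nM, a limit of the assay.

From compound 2 the change nitro in place of methoxy on an aromatic carbon brings an at least 5.2-fold higher number from compound 2 to compound 1 (0.72 log units; beyond the scatter), and the change methoxy in place of hydrogen on an aromatic carbon brings an at least 5.2-fold higher number from compound 2 to compound 3 (0.72 log units; beyond the scatter). Between compound 1 and compound 3 the step is a step that the two limits leave unreadable from compound 1 to compound 3, both values sitting at the limit of > 50000 nM in this assay, at which 2 of the 3 values shown sit.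

Compound 4 `COc1ccc(-c2cn(C(C)=O)c(=O)n2-c2cc(OC)c(OC)c(OC)c2)cc1[N+](=O)[O-]` is not yet measured in this assay; it arises from compound 3 by nitro in place of methoxy on an aromatic carbon. The same kind of change links compound 2 to compound 1, though there the place is para to a large group, whereas here it is ortho to a methoxy group and meta to a large group. The earlier step of an at least 5.2-fold higher number from compound 2 to compound 1 (0.72 log units; beyond the scatter) raised the number, and compound 3 already stands at the limit of > 50000 nM in this assay, at which 2 of the 3 values shown sit. Compound 4 is therefore expected to remain at that limit, the expected step being a step that the limit leaves unreadable from compound 3 to compound 4. Compound 4 is estimated at 70000 nM, within 15000 nM to 300000 nM.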

Compound 4, half-maximal inhibitory concentration: 35700 nM
Beside the measured number, compound 4's estimate is 2.0-fold (0.29 log units) above it; low and high end bracket the measured number.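

In this assay, nitro in place of methoxy on an aromatic carbon does not carry over from one core to another as a fixed step: the same change on two cores in this assay, an at least 5.2-fold higher number (0.72 log units; beyond the scatter) from compound 2 to compound 1 and an at least 1.4-fold lower number (0.14 log units; that floor lies within the scatter) from compound 3 to compound 4, at least 7.3-fold (0.86 log units) apart, beyond the scatter of two such steps

On the core of compound 3 the change gives an at least 1.4-fold lower number from compound 3 to compound 4 (0.14 log units; that floor lies within the scatter), a floor only, while nitro in place of hydrogen gives a 3.8-fold higher number from compound 2 to compound 4 (0.57 log units; beyond the scatter). Compound 3 gives > 50000 nM, a limit of the assay, so the true size of the methoxy-to-nitro step on this core and any reason for the gap between the cores remain unknown.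

Left open is what an amine or a carboxylic acid on the same aromatic carbon would give relative to compound 2. Also open, from the compounds shown here alone, is whether a longer alkoxy chain there would follow compound 3 or compound 4.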